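This account rests on a few compounds, and the source may have more. Where it says the series, first, only, none or still open, it means among the compounds named here.

Compound 1 `CNC(=O)c1cc(C(=O)NC2CC2)cn(Cc2cccc(OC)c2)c1=O` is the anchor of this short series. Among the measured compounds shown here, in a physicochemical assay for solubility (on this read-out higher numbers stand for higher solubility and lower numbers for lower solubility), compound 1 gives 79 ug/mL, and that is the only plain number among the three values recorded. Compound 2 `CNC(=O)c1cc(C(=O)NCCC2CCOCC2)cn(Cc2ccccc2)c1=O` in this assay is reported only as >= 127 ug/mL, a limit. Compound 3 `CNC(=O)c1ccc(=O)n(Cc2cc(Br)ccc2F)c1` in this assay is likewise reported only as >= 143 ug/mL, a limit. These two limits are described by the limit of >= 127 ug/mL in this assay, at which 1 of the 3 values shown sits, and (the limit of >= 143 ug/mL in this assay, at which 1 of the 3 values shown sits), so compound 1, with its measured number, sits below both of them.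

The step that remains unmeasured leads to compound 4 `CNC(=O)c1cc(C(=O)NC2CC2)cn(Cc2cccc3occc23)c1=O`. The change from compound 1 is 1-benzofuran-4-yl in place of 3-methoxyphenyl on a saturated chain carbon bound to an aromatic nitrogen. For the measured compounds named here, no measured step between any pair of compounds here involves this kind of change, so the direction must be estimated rather than read off. The expectation is that the step of a 2.3-fold lower number from compound 1 to compound 4 (0.35 log units; beyond the scatter) goes downward in this assay, by a margin somewhat beyond the usual scatter. Compound 4 is therefore expected to give about 35 ug/mL in this assay, within a range from 12 ug/mL to 100 ug/mL.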

Compound 4, solubility: >= 110 ug/mL
Compound 4: no number, only a limit; the forecaster's own chance of this, stated with the estimate: 5%; at least 3.1-fold (0.49 log units) between middle value and limit.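

Among the compounds shown here, this is the first view of a change on a saturated chain carbon bound to an aromatic nitrogen with the rest of compound 1 held constant: in this assay, 1-benzofuran-4-yl in place of 3-methoxyphenyl gives an at least 1.3-fold higher number from compound 1 to compound 4 (0.14 log units; that floor lies within the scatter). Compound 4 is reported only as a limit, not a number: the limit of >= 110 ug/mL in this assay, at which 1 of the 4 values shown sits. This place therefore takes a group of one five-membered and one six-membered aromatic ring in place of a single six-membered aromatic ring with no fall on this read-out.

On these data alone, how far compound 4 lies past its limit remains open, so the step has a floor and no known top. Also open, as far as these compounds go, is whether a phenyl group carrying an amine or a carboxylic acid at this place would give a plain number or another limit in this assay.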